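Side-chain swap at the amide-bearing carbon, tail flick

A few compounds are considered here, and "the series" means these few. Any claim that something is new, unique, unknown or untested is made for them only; others in the source may bear on it.

Measured so far:
compound 1 `C[C@@H](O)[C@H](NC(=O)CN(c1ncnc2c1ncn2C1CCCCO1)C1CC1)C(=O)OCc1ccccc1`: 23.6%
compound 2 `CSCC[C@H](NC(=O)CN(c1ncnc2c1ncn2C1CCCCO1)C1CC1)C(=O)OCc1ccccc1`: 30%

In a functional assay on the whole organism (Tail, strain ICR) with Mus musculus as the target, in the tail flick test, with a stated time of 30 min, at a dose of 25 umol/kg by the oral route (a lower number here means a weaker effect, a higher number a stronger effect of the compound at the dose given), compound 1 gives 23.6% and compound 2 gives 30%. Within the data shown here, compound 2 holds the upper of the two numbers, but the only step on record, a number 6.4 percentage points higher from compound 1 to compound 2 (within the scatter), is within the scatter, so the two compounds cannot be told apart on this assay.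

Compound 3 `CC(C)[C@H](NC(=O)CN(c1ncnc2c1ncn2C1CCCCO1)C1CC1)C(=O)OCc1ccccc1` is the next variation at the same place: isopropyl in place of 2-(methylsulfanyl)ethyl on a saturated chain carbon bound to an amide-type nitrogen and a carbonyl carbon. Among the measured compounds shown here, the one step that bears on it is the earlier change at this position, a number 6.4 percentage points higher from compound 1 to compound 2 (within the scatter), which stayed within the scatter. On that basis no step beyond the scatter is expected from compound 2 to compound 3 in this assay, in either direction. Compound 3 is therefore estimated at 27%, with a range of 12% to 42%, which corresponds to an expected step of a number 3 percentage points lower from compound 2 to compound 3 (within the scatter).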

Compound 3, a percentage reported as activity, at one dose (the size of the read-out at that dose, not a potency): 21.8%
The estimate for compound 3 lay 5.2 percentage points above the measured number; low and high end bracket the measured number.
By their numbers in this assay, from the lowest: compounds 3, 1 and 2 (each within the scatter of the next).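

In this assay the change from 2-(methylsulfanyl)ethyl to isopropyl gives a number 8.2 percentage points lower from compound 2 to compound 3 (within the scatter), and the change from 1-hydroxyethyl to isopropyl gives a number 1.8 percentage points lower from compound 1 to compound 3 (within the scatter). The three groups on the saturated chain carbon bound to an amide-type nitrogen and a carbonyl carbon therefore cannot be told apart in this read-out, even though isopropyl carries neither the sulfur atom of 2-(methylsulfanyl)ethyl nor any hydrogen-bond acceptor. No measurement on hand bears on why the three compounds fall so close together.

On these data alone, whether an amine, a carboxylic acid or a longer chain at this place would move the read-out beyond the scatter remains open. A read-out at a single dose also leaves open whether any of the three compounds would give a stronger or weaker effect than the others at a different dose.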